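Piperidine to methylpiperazine swap on a second amide core

A few compounds are considered here, and "the series" means these few. Any claim that something is new, unique, unknown or untested is made for them only; others in the source may bear on it.

Compound 1 `COc1cc2c(Oc3ccc(NC(=O)c4cc(-c5ccc(C(F)(F)F)cc5)ccn4)cc3F)ccnc2cc1OCCCN1CCCCC1` gives 870 nM in a functional assay on MKN-45 cells (Homo sapiens) for cytotoxicity, read by MTT assay, with a stated time of 72 h; a lower number here means a stronger inhibitor, a higher number a weaker inhibitor. Compound 2 `COc1cc2c(Oc3ccc(NC(=O)c4cc(-c5ccc(C(F)(F)F)cc5)ccn4)cc3F)ccnc2cc1OCCCN1CCN(C)CC1` gives 330 nM. The change between them is 4-methylpiperazin-1-yl in place of piperidin-1-yl on a saturated chain carbon, three bonds along the chain from an oxygen on an aromatic ring, and the step is a 2.6-fold lower number from compound 1 to compound 2 (0.42 log units; beyond the scatter). Compound 3 `COc1cc2c(Oc3ccc(NC(=O)c4nccc(-c5ccc(C)cc5)n4)cc3F)ccnc2cc1OCCCN1CCCCC1` carries a different core; the difference between the two cores is not broken down here. In this assay compound 3 gives 580 nM, within the scatter of both compound 1 and compound 2. Compound 4 `COc1cc2c(Oc3ccc(NC(=O)c4nccc(-c5ccc(C)cc5)n4)cc3F)ccnc2cc1OCCCN1CCN(C)CC1` is not yet measured; it differs from compound 3 by 4-methylpiperazin-1-yl in place of piperidin-1-yl on a saturated chain carbon, three bonds along the chain from an oxygen on an aromatic ring, the same change at the same place as in the first pair. Because compound 1 to compound 2 showed a 2.6-fold lower number from compound 1 to compound 2 (0.42 log units; beyond the scatter), a step of about a 2.5-fold lower number from compound 3 to compound 4 (0.40 log units; beyond the scatter) is expected for compound 4. Compound 4 is estimated at 230 nM, with a range of 100 nM to 520 nM expected.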

Compound 4, half-maximal inhibitory concentration: 340 nM
Compound 4: the middle estimate sits 1.5-fold (0.17 log units) below what was measured; the range from low to high includes it.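

The same swap on the core of compound 3 gives a 1.7-fold lower number from compound 3 to compound 4 (0.23 log units; within the scatter) in this assay. Set beside the step on the core of compound 1, it shows no difference that can be told apart from measurement noise: the same change on two cores in this assay, a 2.6-fold lower number (0.42 log units; beyond the scatter) from compound 1 to compound 2 and a 1.7-fold lower number (0.23 log units; within the scatter) from compound 3 to compound 4, 1.5-fold (0.19 log units) apart, within the scatter of two such steps The two steps are compatible with one shared effect of the swap on both cores, but only the step from compound 1 to compound 2 stands clear of the scatter on its own, and two cores do not establish a rule for the series.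

Open, going by these compounds, is whether morpholine in place of these rings, or a longer chain than 3-(4-methylpiperazin-1-yl)propyl, would behave alike on both cores. Compound 1 and compound 3 differ in more than one place, so the contribution of each core itself also remains unresolved.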